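The compounds below may be only part of what the source reports. "The series", "measured", "known", "first", "only" and "open" are said of these compounds alone.

Compound 1 `COC(=O)c1sc2ncnc(Nc3cc(C)cn(C)c3=O)c2c1C` and compound 2 `Cc1cc(Nc2ncnc3sc(C(N)=O)c(C)c23)c(=O)n(C)c1` share one core and differ only at the carbonyl carbon. In an assay on isolated protein for inhibition of MAP kinase-interacting serine/threonine-protein kinase 1 (Homo sapiens), read by ADP-Glo, with a stated time of 10 min (on this read-out lower numbers stand for stronger inhibition and higher numbers for weaker inhibition), compound 1 gives only a limit, > 10000 nM. Compound 2 likewise gives only a limit in this assay, > 10000 nM. The step that the two limits leave unreadable from compound 1 to compound 2 is therefore unreadable in size, as both values sit at the limit of > 10000 nM in this assay, at which 2 of the 2 values shown sit. Compound 3 `CCNC(=O)c1sc2ncnc(Nc3cc(C)cn(C)c3=O)c2c1C` arises from compound 2 by ethyl in place of hydrogen on an amide-type nitrogen. Among the measured compounds shown here, no measured step bears directly on this change; the single step recorded, between compound 1 and compound 2, leaves only two limits and no number. With both neighbours at the limit, compound 3 is expected to remain near that limit, so the expected step that the limit leaves unreadable from compound 2 to compound 3 is none beyond the scatter. Compound 3 is accordingly estimated at 15000 nM in this assay, between 3000 nM and 60000 nM, and most likely again reported only as a limit.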

Compound 3, inhibition constant: > 10000 nM
Compound 3 ended at the assay's limit; the forecaster's own chance of this, stated with the estimate: 75%; the middle value is on the limit's open side.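

Among the compounds shown here, no step among compound 1, compound 2 and compound 3 can be read, since each value is only a limit: the limit of > 10000 nM in this assay, at which 3 of the 3 values shown sit. What these compounds leave open is how strongly any of them inhibits the kinase, and whether changing the group on the carbonyl carbon alters that at all.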